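This account rests on a few compounds, and the source may have more. Where it says the series, first, only, none or still open, it means among the compounds named here.

Measured so far:
Compound 1, `CCCCN(CCCC)c1nc2c(ncn2-c2ccccc2)c(=O)n1-c1ccccc1`: 20400 nM
Compound 2, `CNc1nc2c(ncn2-c2ccccc2)c(=O)n1-c1ccccc1`: > 100000 nM

In a functional assay on HepG2 cells (Homo sapiens) for cytotoxicity, read by MTT assay, with a stated time of 72 h (a lower number here means a stronger inhibitor, a higher number a weaker inhibitor), compound 1 gives 20400 nM. Compound 2 reaches only a limit, > 100000 nM, where (the limit of > 100000 nM in this assay, at which 1 of the 2 values shown sits). Between them lies an at least 4.9-fold higher number from compound 1 to compound 2 (0.69 log units; beyond the scatter). Compound 2 thus stands at the weak end of the two values, known only as a limit. Compound 3 `CCNc1nc2c(ncn2-c2ccccc2)c(=O)n1-c1ccccc1` differs from compound 2 by methyl in place of hydrogen on a saturated chain carbon bound to a nitrogen on an aromatic ring. Among the compounds with values here, the one step that bears on this is an at least 4.9-fold higher number from compound 1 to compound 2 (0.69 log units; beyond the scatter), a much larger change of the amine substituent than the one here, so the expected step in this assay is small, toward a lower number or none beyond the scatter. Compound 3 is therefore estimated at 100000 nM, between 40000 nM and 300000 nM, an expected step of a number no higher from compound 2 to compound 3 (the limit leaves the size open).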

Compound 3, half-maximal inhibitory concentration: > 100000 nM
Compound 3: only a limit was reported; the forecaster's own chance of this, stated with the estimate: 55%; the middle value lies on the limit itself.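

In this assay compound 3 gives > 100000 nM, which is a limit of the assay. The step from compound 2 to compound 3 therefore cannot be read, since both values are limits: the limit of > 100000 nM in this assay, at which 2 of the 3 values shown sit.

Ethylamino in place of dibutylamino gives an at least 4.9-fold higher number from compound 1 to compound 3 (0.69 log units; beyond the scatter), so methyl on this chain carbon does not bring the value back to that of compound 1.

From the compounds shown here alone, whether compound 2 and compound 3 differ at all beyond the limit stays open. So does whether a butylamino group, with a single longer chain on the nitrogen, would give a measurable value.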